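A few compounds are considered here, and "the series" means these few. Any claim that something is new, unique, unknown or untested is made for them only; others in the source may bear on it.

Compound 2 `Cc1cc(=O)n(-c2ccccc2OC(F)(F)F)nc1C(=O)Nc1ccc(Oc2ncnc3c2ccn3C)cc1` carries the highest of the two numbers recorded in a functional assay on PC-3 cells (Homo sapiens) for cytotoxicity, read by MTT assay, with a stated time of 72 h (on this read-out higher numbers stand for weaker inhibition and lower numbers for stronger inhibition), where compound 2 gives 5160 nM. The nearest number belongs to compound 1 `Cc1cc(=O)n(-c2ccc(Br)cc2F)nc1C(=O)Nc1ccc(Oc2ncnc3[nH]ccc23)cc1`, which in this assay gives 2730 nM; the two values sit within the scatter of each other, so no order between them can be read.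

Compound 3 `Cc1cc(=O)n(-c2ccc(Br)cc2F)nc1C(=O)Nc1ccc(Oc2ncnc3c2ccn3C)cc1` has not been measured. It differs from compound 2 in one place: 4-bromo-2-fluorophenyl in place of 2-(trifluoromethoxy)phenyl on an aromatic nitrogen, on an aromatic nitrogen of a six-membered aromatic ring with two nitrogens. Compound 1 already carries this 4-bromo-2-fluorophenyl group on a closely related core, and its value gives no sign that the group moves the number far. Among the compounds with values here, no step between measured compounds is recorded for this exchange, so the expected step from compound 2 to compound 3 is a 1.5-fold lower number from compound 2 to compound 3 (0.17 log units; within the scatter), not beyond the scatter. Compound 3 is therefore estimated at 3500 nM, with a likely range from 1200 nM to 10000 nM.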

Compound 3, half-maximal inhibitory concentration: 18800 nM
For compound 3 the middle estimate is 5.4-fold (0.73 log units) below the measured one, and the stated range ends below it.
By their numbers in this assay, from the lowest: compounds 1 and 2 (each within the scatter of the next); then compound 3.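

In this assay 4-bromo-2-fluorophenyl in place of 2-(trifluoromethoxy)phenyl on the aromatic nitrogen gives a 3.6-fold higher number from compound 2 to compound 3 (0.56 log units; beyond the scatter) with the rest of the molecule unchanged, so the choice of group at this position does bear on the number. With 4-bromo-2-fluorophenyl held fixed, methyl in place of hydrogen on an aromatic nitrogen of the core gives a 6.9-fold higher number from compound 1 to compound 3 (0.84 log units; beyond the scatter) and thus shows that the value of compound 1 does not carry over to the methylated core. No measurement shown here explains either step.

The compounds shown leave open whether methyl in place of hydrogen gives a step of similar size with 2-(trifluoromethoxy)phenyl on the aromatic nitrogen, and whether the bromine or the fluorine of the entering group goes with the higher number. They also leave open how an unsubstituted phenyl at this position, or an ethyl group in place of the methyl on the core, would read.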